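A few compounds are considered here, and "the series" means these few. Any claim that something is new, unique, unknown or untested is made for them only; others in the source may bear on it.

Compound 2 `CCOC(=O)Cn1c(=O)c(-c2ccc(OC)cc2)cc2c(OC)cc(OC)cc21` shares its core with compound 1 `COc1ccc(-c2cc3cccc(OC)c3nc2O)cc1` and compound 3 `CCN(CC)C(=O)Cn1c(=O)c(-c2ccc(OC)cc2)cc2c(OC)cc(OC)cc21`. In a functional assay on T47D cells (Homo sapiens) for cytotoxicity, read by colorimetric assay and MTT assay (a higher number here means a weaker inhibitor, a lower number a stronger inhibitor), compound 2 gives 10000 nM, and it stands level with both of its neighbours: in this assay compound 1 gives 10000 nM and compound 3 gives 10000 nM. Going by the values given here, the only measured step, no change at the digits printed from compound 2 to compound 3 (within the scatter), alters the chain that hangs from the aromatic nitrogen and lies within the scatter.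

Compound 4 `COc1ccc(-c2cc3c(OC)cc(OC)cc3n(CCC#N)c2=O)cc1` is the next compound to be measured. It differs from compound 2 by cyanomethyl in place of ethoxycarbonyl on a saturated chain carbon bound to an aromatic nitrogen. Among the compounds with values here, this change sits on the same chain carbon bound to the aromatic nitrogen that the one measured step also touched, so that step is the only guide available.

Because the step of no change at the digits printed from compound 2 to compound 3 (within the scatter) stays within the scatter, compound 4 is expected to show no change at the digits printed from compound 2 to compound 4 (within the scatter), meaning no shift beyond the scatter. Compound 4 is therefore estimated at 10000 nM in this assay, with a likely range from 4000 nM to 25000 nM.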

Compound 4, half-maximal inhibitory concentration: 10000 nM
The estimate for compound 4 equals the measured number at the digits printed; the measured number falls inside the stated range.
By their numbers in this assay, from the lowest: compounds 1, 2, 3 and 4 (each within the scatter of the next).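

At this position, on a saturated chain carbon bound to an aromatic nitrogen, this assay now records no change at the digits printed from compound 2 to compound 4 (within the scatter) for cyanomethyl in place of ethoxycarbonyl, and no change at the digits printed from compound 3 to compound 4 (within the scatter) for cyanomethyl in place of diethylcarbamoyl. The carbonyl group carried by both earlier chains can thus give way to a nitrile, with fewer heavy atoms and one hydrogen-bond acceptor fewer than ethoxycarbonyl, and the reading stays level. No measurement available here explains this sameness.

Every compound shown reads alike, so no group has yet moved the value at this position. A carboxylic acid or an amine on this chain, or a longer chain, would test whether the position responds to change at all.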